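Swapping a Fluorophenyl for a Furan on Cytotoxicity

This account rests on a few compounds, and the source may have more. Where it says the series, first, only, none or still open, it means among the compounds named here.

Among the compounds with values here, compound 2 `Cc1ccc2c(NCc3ccc(NC(=O)C4CCN(Cc5ccccc5F)CC4)cc3)nc(N(C)C)nc2c1` is one of two compounds measured in a functional assay on SV5A8 cells (Homo sapiens) for cytotoxicity; on this read-out higher numbers stand for weaker inhibition and lower numbers for stronger inhibition. In this assay compound 2 gives only a limit, > 6670 nM, so its exact value is not known. The related compound 1 `Cc1ccc2c(NCc3ccc(NC(=O)C4CCN(Cc5cccc(F)c5)CC4)cc3)nc(N(C)C)nc2c1` also gives only a limit in this assay, > 4170 nM. The two differ by a step that the two limits leave unreadable from compound 1 to compound 2, and because both values are limits (the limit of > 4170 nM in this assay, at which 1 of the 2 values shown sits, and (the limit of > 6670 nM in this assay, at which 1 of the 2 values shown sits)) the size of that step cannot be read. Compound 3 `Cc1ccc2c(NCc3ccc(NC(=O)C4CCN(Cc5ccco5)CC4)cc3)nc(N(C)C)nc2c1` is not yet measured; it differs from compound 2 by furan-2-yl in place of 2-fluorophenyl on a saturated chain carbon bound to an amine nitrogen in a ring. Within the data shown here, no measured step describes this change, and the one measured step is unreadable, so no direction can be drawn from it. Compound 3 is therefore expected to remain near or beyond the limit, with an estimated step that the limit leaves unreadable from compound 2 to compound 3. Compound 3 is expected to give 10000 nM, within a range from 4000 nM to 30000 nM.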

Compound 3, half-maximal inhibitory concentration: > 20000 nM
Compound 3 ended at the assay's limit (the forecaster's own chance of this, stated with the estimate: 85%); middle value at least 2.0-fold (0.30 log units) from the limit.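

Within the data shown here, compound 1, compound 2 and compound 3 all give only limits, not exact numbers, so no step among them can be read. The compounds shown leave open where the true value of each lies in this assay, and so whether swapping 2-fluorophenyl for furan-2-yl changes anything.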